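One More Methoxy Group on Compound 3

This account rests on a few compounds, and the source may have more. Where it says the series, first, only, none or still open, it means among the compounds named here.

Measured so far in a functional assay on MCF7 cells (Homo sapiens) for inhibition, read by sulforhodamine B assay, with a stated time of 48 h (a higher number here means a weaker inhibitor of growth, a lower number a stronger inhibitor of growth), are these compounds:
Compound 1 `CC1(/C=C/c2ccccc2)C=CC(=O)O1` at 95300 nM
Compound 2 `CC1(/C=C/c2ccc(C(F)(F)F)cc2)C=CC(=O)O1` at 20400 nM
Compound 3 `COc1ccc(/C=C/C2(C)C=CC(=O)O2)c(OC)c1` at 43500 nM

Compound 3 stands in the middle of these three, with a lower number than compound 1 and a higher number than compound 2. Compound 4 `COc1cc(OC)c(OC)cc1/C=C/C1(C)C=CC(=O)O1` differs from compound 3 by one change methoxy in place of hydrogen on an aromatic carbon. For the measured compounds named here, no measured step shows this exact change. The closest guide puts a different group on an aromatic carbon, trifluoromethyl in place of hydrogen, and it gave a 4.7-fold lower number from compound 1 to compound 2 (0.67 log units; beyond the scatter) as the result. The values offer a second hint: compound 3 carries methoxy groups and stands lower than compound 1 in this assay as well, with compound 1 at 95300 nM and compound 3 at 43500 nM. Both hints point towards a lower number, though neither tests this methoxy group directly. The expected step is a 1.5-fold lower number from compound 3 to compound 4 (0.16 log units; within the scatter) and it is a small one, perhaps not clearly beyond the usual scatter. For compound 4 the estimated value is 30000 nM (expected range 12000 nM to 70000 nM).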

Compound 4, concentration for total growth inhibition: 144000 nM
Compound 4: middle estimate off by 4.8-fold (0.68 log units), on the low side, and the stated range ends below it.
By their numbers in this assay, from the lowest: compound 2; then compound 3; then compounds 1 and 4 (each within the scatter of the next).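

In this assay, methoxy placed on this carbon, ortho to a methoxy group, meta to a group of 9 heavy atoms and para to a methoxy group, gives a 3.3-fold higher number from compound 3 to compound 4 (0.52 log units; beyond the scatter), so here the added group weakens growth inhibition. For the compounds shown here, the only earlier step, a 4.7-fold lower number from compound 1 to compound 2 (0.67 log units; beyond the scatter), ran the opposite way, with a different group on a different aromatic carbon, so replacing an aromatic hydrogen does not lower the number in every case. Nothing available here bears on why this number rose.

The compounds shown cannot separate the effect of this position from the effect of the methoxy group itself. A hydroxyl group or an amine on this same carbon would show whether the rise is specific to methoxy or also appears with other groups there.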